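The source may report more compounds than this note shows. Statements on the series, on what has been measured and on what is new or still open speak of the compounds shown alone.

Compound 1 `N=C(S)CCn1ncccc1=S` was tested in a functional assay on the whole organism (stomach) for inhibition, with Rattus norvegicus as the target, at a dose of 100 mg/kg by the intraduodenal route (on this read-out higher numbers stand for more inhibition at the one dose given (going by the name of the read-out) and lower numbers for less inhibition), where compound 1 gives 50%. Compound 2 `Cc1ccc(=S)n(CCC(=N)S)n1` carries the change (methyl in place of hydrogen on an aromatic carbon); in this assay compound 2 gives 48.5%, so that the step of a number 1.5 percentage points lower from compound 1 to compound 2 (within the scatter). Compound 3 `N=C(S)CCn1nc(-c2ccccc2)ccc1=O` rests on a different core, and the difference between the two cores is not broken down here. In this assay compound 3 gives 53.7%, a number within the scatter of both other values. Compound 4 `Cc1ccc(-c2ccc(=O)n(CCC(=N)S)n2)cc1` has not yet been measured. It differs from compound 3 by methyl in place of hydrogen on an aromatic carbon. This is the same kind of change as from compound 1 to compound 2, though the place differs: there the methyl entered on a six-membered aromatic ring with 2 nitrogen, next to the ring nitrogen, meta to a group of 5 heavy atoms and para to a group of 1 heavy atom, whereas here it enters on a six-membered aromatic ring of carbon only, para to a large group. Because the step of a number 1.5 percentage points lower from compound 1 to compound 2 (within the scatter) lay within the scatter, a similarly small step is expected here, a number 1.7 percentage points lower from compound 3 to compound 4 (within the scatter). Compound 4 is therefore expected to give about 52% in this assay, most likely between 40% and 64%.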

Compound 4, a percentage reported as inhibition, in the whole organism at one dose (the size of the read-out at that dose, not a potency): 18.2%
Compound 4: the middle estimate sits 33.8 percentage points above what was measured, outside the stated range (below it).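

In this assay, methyl in place of hydrogen on an aromatic carbon did not behave alike on the two cores: the same change on two cores in this assay, a number 1.5 percentage points lower (within the scatter) from compound 1 to compound 2 and a number 35.5 percentage points lower (beyond the scatter) from compound 3 to compound 4, 34 percentage points apart, beyond the scatter of two such steps. The new step, a number 35.5 percentage points lower from compound 3 to compound 4 (beyond the scatter), is large and arises with the methyl on a six-membered aromatic ring of carbon only, para to a large group, whereas the earlier step, a number 1.5 percentage points lower from compound 1 to compound 2 (within the scatter), gave no sign of such a loss. The two methyl groups differ in both core and place, and this single pair of steps does not show which of the two sets the size of the step, nor does a reading at one dose in the whole organism show a change in potency.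

Going by these compounds, it remains open whether a chlorine atom, a methoxy group or a hydroxyl group in the same place would give a loss like that of methyl. On these data alone, it is also open whether a longer chain on the ring nitrogen would alter the size of the step.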